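What a fluoro group might do to compound 2

A few compounds are considered here, and "the series" means these few. Any claim that something is new, unique, unknown or untested is made for them only; others in the source may bear on it.

- compound 1 `Cc1cccc(C(=O)Nc2ccc(C#N)cc2)c1O` gives 8980 nM
- compound 2 `N#Cc1ccc(NC(=O)c2ccccc2O)cc1` gives 5370 nM

These two numbers come from a functional assay on KG-1 cells (Homo sapiens) for cytotoxicity, read by luminescence and CellTiter-Glo, with a stated time of 3 days (a lower number here means a stronger inhibitor, a higher number a weaker inhibitor), and they are all that has been measured so far. Compound 2 stands at 5370 nM and lies within the scatter of compound 1 at 8980 nM, so neither can be called the stronger.

The next compound, compound 3 `N#Cc1ccc(NC(=O)c2cccc(F)c2O)cc1`, differs from compound 2 in one place: fluoro in place of hydrogen on an aromatic carbon. This puts fluoro in place of hydrogen on an aromatic carbon, ortho to a hydroxy group.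

Among the compounds with values here, only one measured step bears on this, and only loosely: a 1.7-fold lower number from compound 1 to compound 2 (0.22 log units; within the scatter), with hydrogen in place of methyl on that same carbon. Within the data shown here, two different groups at this carbon thus left the numbers within the scatter, though a single step is thin evidence and no fluoro compound has been measured. No step beyond the scatter is therefore expected in this assay, in either direction. The expected step is a 1.2-fold lower number from compound 2 to compound 3 (0.08 log units; within the scatter). For compound 3 the estimated value is 4500 nM, with an expected range from 1800 nM to 11000 nM.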

Compound 3, half-maximal inhibitory concentration: 9690 nM
Compound 3: middle estimate off by 2.2-fold (0.33 log units), on the low side; the measured number falls inside the stated range.
By their numbers in this assay, from the lowest: compounds 2, 1 and 3 (each within the scatter of the next).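

In this assay, fluoro in place of hydrogen on this aromatic carbon, ortho to a hydroxy group, gives a step that stays within the scatter (a 1.8-fold higher number from compound 2 to compound 3 (0.26 log units; within the scatter)), and fluoro in place of methyl at the same carbon does too (a 1.1-fold higher number from compound 1 to compound 3 (0.03 log units; within the scatter)). Fluoro is thus a third group at this position alongside hydrogen and methyl, and the earlier single step between hydrogen and methyl now has company: all three pairs lie within the scatter, so this assay does not separate the three compounds, and none of them can be called the stronger or the weaker. Nothing measured here explains why these groups give numbers that cannot be told apart.

Whether any group at this carbon can move the number beyond the scatter stays open, since a chlorine atom, a methoxy group, an amine or a carboxylic acid are not among the compounds shown. From the compounds shown here alone, it also stays open whether fluoro would give a similar result on the other carbons of this ring.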